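The compounds below may be only part of what the source reports. "The series", "measured", "known", "first", "only" and "open" are said of these compounds alone.

Among the measured compounds shown here, compound 2 `CC(C)CN1CC(c2nc(-c3cccc(Cl)c3)no2)CC1=O` is the only member of this small set with a number in an in vitro functional assay on HEK293-A cells for negative allosteric modulation of metabotropic glutamate receptor 5 (Homo sapiens), read by FLIPR and calcium flux; on this read-out lower numbers stand for stronger inhibition and higher numbers for weaker inhibition; there compound 2 gives 920 nM. Compound 1 `O=C1CC(c2nc(-c3cccc(Cl)c3)no2)CN1c1ccc(Cl)c(Cl)c1` has no number: in this assay compound 1 gives > 10000 nM, which is a limit of the assay and not a measured value, as shown by the limit of > 10000 nM in this assay, at which 1 of the 2 values shown sits. For the measured compounds named here, the single measured step joins these two: an at least 10-fold lower number from compound 1 to compound 2 (1.03 log units; beyond the scatter), so exchanging the 3,4-dichlorophenyl group on the ring nitrogen for isobutyl brought the compound from a limit to a measurable number.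

Compound 3 `Cc1ccc(N2CC(c3nc(-c4cccc(Cl)c4)no3)CC2=O)cc1C` differs from compound 2 in 3,4-dimethylphenyl in place of isobutyl on an amide-type nitrogen in a ring. Going by the values given here, this returns an aromatic ring to the same ring nitrogen that carries an aryl group in compound 1, and that single measured step is the only evidence bearing on it. Since the reverse exchange, from aryl to isobutyl, gave a large drop in the number, the change from compound 2 to compound 3 is expected to raise the number in this assay by a large step, with a real chance that only a limit is reported. Compound 3 is therefore expected to give about 8000 nM, within a range of 2000 nM to 30000 nM, which corresponds to an expected step of an 8.7-fold higher number from compound 2 to compound 3 (0.94 log units; beyond the scatter).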

Compound 3, half-maximal inhibitory concentration: > 10000 nM
Compound 3: only a limit was reported (the forecaster's own chance of this, stated with the estimate: 45%); middle value at least 1.2-fold (0.09 log units) away from the limit.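

In this assay, a second aryl group on the ring nitrogen gives the same outcome as the first, with an at least 10-fold higher number from compound 2 to compound 3 (1.03 log units; beyond the scatter), so the loss of a measurable number is no longer tied to the 3,4-dichlorophenyl group alone. The step between compound 1 and compound 3 cannot be read, since both ends are limits of the assay and not numbers, so nothing can be said about the exchange of chlorine for methyl on the aryl ring except that it did not bring a number back. On this nitrogen, isobutyl in compound 2 is now the only group of the three to give a number, while the two aryl compounds, compound 1 and compound 3, stop at a limit: the limit of > 10000 nM in this assay, at which 2 of the 3 values shown sit.

The compounds shown leave open whether the aromatic ring or the larger group matters, as 3,4-dimethylphenyl differs from isobutyl in both ring and heavy-atom count, and a cyclohexyl or benzyl group on this nitrogen would bear on that. They also leave open how the number responds to a longer chain or to a chain carrying an amine at this position.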